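The compounds below may be only part of what the source reports. "The series", "measured", "known", "first", "only" and "open" are said of these compounds alone.

Measured compounds in an ADME assay on Vero cells (Chlorocebus sabaeus) for cytotoxicity, read by sulforhodamine B assay, with a stated time of 3 days; on this read-out higher numbers stand for lower toxicity in this test and lower numbers for higher toxicity in this test:
- compound 1 `COc1ccc(C2C(C(=O)Nc3ccc(Cl)cc3)=C(C)NC(C)=C2C(=O)Nc2ccc(Cl)cc2)cc1` gives 20 ug/mL
- compound 2 `COc1cc(C2C(C(=O)Nc3ccc(Cl)cc3)=C(C)NC(C)=C2C(=O)Nc2ccc(Cl)cc2)ccc1O` gives 250 ug/mL

Compound 2 holds the highest number of the two measured compounds in this assay; its nearest neighbour is compound 1, and the step of a 13-fold higher number from compound 1 to compound 2 (1.10 log units; beyond the scatter) lies well beyond the scatter. Compound 3 `CC1=C(C(=O)Nc2ccc(Cl)cc2)C(c2ccncc2)C(C(=O)Nc2ccc(Cl)cc2)=C(C)N1` is the next compound to be measured. It differs from compound 2 in one place: pyridin-4-yl in place of 4-hydroxy-3-methoxyphenyl on a saturated ring carbon. Going by the values given here, only one measured step bears on this position, namely a 13-fold higher number from compound 1 to compound 2 (1.10 log units; beyond the scatter), where the hydroxyl group on the aryl ring came in together with the shift of the methoxy group. Among the compounds with values here, compound 3 has neither the hydroxyl nor the methoxy group, so the single step that is known gives no direct guide for the pyridin-4-yl group; it only shows that this position moves the read-out strongly. A step back toward the number of compound 1 is therefore expected, and compound 3 is estimated to give 40 ug/mL in this assay, within a range from 10 ug/mL to 160 ug/mL. This means an expected step of a 6.3-fold lower number from compound 2 to compound 3 (0.80 log units; beyond the scatter).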

Compound 3, half-maximal cytotoxic concentration: 78 ug/mL
Beside the measured number, compound 3's estimate is 2.0-fold (0.29 log units) below it; low and high end bracket the measured number.
By their numbers in this assay, from the lowest: compound 1; then compound 3; then compound 2.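

In this assay, the pyridin-4-yl group on the saturated ring carbon gives a 3.9-fold higher number from compound 1 to compound 3 (0.59 log units; beyond the scatter), so a number above that of the 4-methoxyphenyl compound does not depend on a hydroxyl group at this position, nor on a carbon-only aromatic ring. The same group still gives a 3.2-fold lower number from compound 2 to compound 3 (0.51 log units; beyond the scatter), which leaves the 4-hydroxy-3-methoxyphenyl group with the highest number of the three and places pyridin-4-yl between the two substituted phenyl groups, each step beyond the usual scatter. The position therefore does not behave as a simple choice between two levels, since three different aromatic groups on this carbon give three separate numbers, and nothing measured here accounts for that order.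

The compounds shown leave open how much of the high number of compound 2 belongs to its hydroxyl group and how much to its methoxy group, a question that a plain phenyl or a 4-hydroxyphenyl group on this carbon would bear on. They also leave open whether the place of the ring nitrogen matters, which a pyridin-3-yl or pyridin-2-yl group would address.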